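The compounds below may be only part of what the source reports. "The series", "measured", "known", "first", "only" and "open" are said of these compounds alone.

Series notes. Compound 2 `CC(=O)OC(C)n1cnc2c(N)nc(I)nc21` carries an acetyl on an oxygen on a saturated carbon; in a functional assay on MOLT-4 cells (Homo sapiens) for inhibition (a higher number here means a weaker inhibitor, a lower number a stronger inhibitor), compound 2 gives 436000 nM. Compound 1 `CC(O)n1cnc2c(N)nc(I)nc21` is the matching hydroxy compound. In this assay compound 1 reaches only the limit of the assay, > 500000 nM. The change hydrogen in place of acetyl on an oxygen on a saturated carbon therefore reads as an at least 1.1-fold higher number from compound 2 to compound 1 (0.05 log units; that floor lies within the scatter). Compound 3 `CC(=O)OC(C)n1cnc2c(S)nc(F)nc21` stands on a second core; how the core of compound 3 differs from the core of compound 2 is not broken down here. In this assay compound 3 likewise gives only the limit, > 500000 nM. Compound 4 `CC(O)n1cnc2c(S)nc(F)nc21` is the unmeasured partner of compound 3 with the same change, (hydrogen in place of acetyl on an oxygen on a saturated carbon), made at the same place. The step from compound 3 to compound 4 in this assay is expected to be small, a number no higher from compound 3 to compound 4 (the limit leaves the size open), resting on an at least 1.1-fold higher number from compound 2 to compound 1 (0.05 log units; that floor lies within the scatter) as the one measured case of this change. Compound 3 itself starts from its limit, > 500000 nM. Given (the limit of > 500000 nM in this assay, at which 2 of the 3 values shown sit), for compound 4 the estimate in this assay is 500000 nM, with a range from 250000 nM to 1000000 nM, and a limit rather than a number is the expected report.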

Compound 4, half-maximal inhibitory concentration: > 500000 nM
Compound 4: no number, only a limit; the forecaster's own chance of this, stated with the estimate: 80%; the middle value sits exactly at the limit.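

In this assay compound 4 gives only a limit, > 500000 nM, and compound 3 also stands at a limit, so no step can be read between the two. The compounds shown leave open whether acetoxy to hydroxy shifts the number at all on the core of compound 3, since the read-out stops at one value: the limit of > 500000 nM in this assay, at which 3 of the 4 values shown sit.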